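Benzyl Carbamate in Place of tert-Butyl

The source may hold more compounds than are shown below. What is called first, only, known or untested is meant among the compounds shown, and "the series" means these compounds.

Compound 2 `C[C@@H]1CN(C(=O)c2nc(Nc3cc(C4CC4)[nH]n3)c3cc(Cl)ccc3n2)CCN1C(=O)OC(C)(C)C` carries a tert-butyl on an oxygen next to a carbonyl group. In an ADME assay on a cell-free system (plasma, Homo sapiens), read by HPLC, with a stated time of 120 min, at 37 degrees C (a higher number here means that more of the compound is left, a lower number that less of the compound is left), compound 2 gives 73.7%. Compound 1 `CC(C)COC(=O)N1CCN(C(=O)c2nc(Nc3cc(C4CC4)[nH]n3)c3cc(Cl)ccc3n2)C[C@H]1C`, with an isobutyl at that oxygen, gives 73.7% in this assay; the step of no change at the digits printed from compound 1 to compound 2 (within the scatter) is within the scatter, and the two stand level as the highest of the three numbers. Compound 3 `CC(OC(=O)N1CCN(C(=O)c2nc(Nc3cc(C4CC4)[nH]n3)c3cc(Cl)ccc3n2)C[C@H]1C)OC(=O)C(C)(C)C` sits furthest from compound 2: in this assay compound 3 gives 49.4%, and the step of a number 24.3 percentage points lower from compound 2 to compound 3 (beyond the scatter) lies beyond the scatter, as does a number 24.3 percentage points lower from compound 1 to compound 3 (beyond the scatter).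

Compound 4 `C[C@@H]1CN(C(=O)c2nc(Nc3cc(C4CC4)[nH]n3)c3cc(Cl)ccc3n2)CCN1C(=O)OCc1ccccc1` differs from compound 2 in one place: benzyl in place of tert-butyl on an oxygen next to a carbonyl group. Among the compounds with values here, the steps that bear on it are the exchange of one alkyl group for another, no change at the digits printed from compound 1 to compound 2 (within the scatter), which left the number unchanged, and the two steps into the 1-(((tert-butyl)carbonyl)oxy)ethyl group, a number 24.3 percentage points lower from compound 1 to compound 3 (beyond the scatter) and a number 24.3 percentage points lower from compound 2 to compound 3 (beyond the scatter), which lowered it. Benzyl, like isobutyl and tert-butyl, contains only carbon, so the expected step of a number 3.7 percentage points lower from compound 2 to compound 4 (within the scatter) is small, with no change beyond the scatter. Compound 4 is therefore expected to give about 70%, within a range from 55% to 85%, in this assay.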

Compound 4, percent of the compound remaining: 86.2%
For compound 4 the middle estimate is 16.2 percentage points below the measured one, outside the stated range (above it).
By their numbers in this assay, from the lowest: compound 3; then compounds 1 and 2 (each within the scatter of the next); then compound 4.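

At the oxygen next to a carbonyl group, the choice among groups of carbon alone turns out to matter in this assay: the level pair of isobutyl and tert-butyl gives way to benzyl with a number 12.5 percentage points higher from compound 2 to compound 4 (beyond the scatter) and with a number 12.5 percentage points higher from compound 1 to compound 4 (beyond the scatter) on the other side of that pair. Benzyl brings one six-membered aromatic ring of carbon only, and with it the range spanned at this position widens to a number 36.8 percentage points higher from compound 3 to compound 4 (beyond the scatter) and places compound 4 at the top of the four numbers, with its steps to all the others beyond the scatter. The compounds thus show that this position can carry the number upward as well as downward, but nothing available gives a reason for the gain.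

The compounds shown leave open whether the gain belongs to the aromatic ring as such or to the way it is attached, which a phenyl directly on the oxygen or a longer chain such as 2-phenylethyl would separate. They also leave open how a pyridylmethyl group, or a benzyl carrying fluorine on its ring, would stand in this assay against compound 4.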